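This account rests on a few compounds, and the source may have more. Where it says the series, first, only, none or still open, it means among the compounds named here.

Measured in a functional assay on Z-138 cells (Homo sapiens) for antiproliferative activity, with a stated time of 72 h; on this read-out lower numbers stand for stronger inhibition and higher numbers for weaker inhibition:
- Compound 1 `CCCC#Cc1cc([C@@H]2O[C@H](CO)[C@@H](O)[C@H]2O)n2ncnc(N)c12`: 20 nM
- Compound 2 `Nc1ncnn2c([C@@H]3O[C@H](CO)[C@@H](O)[C@H]3O)cc(C#CC3CC3)c12`: 20 nM
- Compound 3 `Cc1ccccc1-c1cc([C@@H]2O[C@H](CO)[C@@H](O)[C@H]2O)n2ncnc(N)c12`: 66000 nM

Of these three, compound 3 has the highest number, which here means the weakest inhibition. The gap is large on both sides: a 3300-fold higher number from compound 1 to compound 3 (3.52 log units; beyond the scatter), and a 3300-fold higher number from compound 2 to compound 3 (3.52 log units; beyond the scatter). Exchanging one triple-bonded group for the other, by contrast, shows nothing beyond the scatter: no change at the digits printed from compound 1 to compound 2 (within the scatter).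

The next compound is compound 4 `Nc1ncnn2c([C@@H]3O[C@H](CO)[C@@H](O)[C@H]3O)cc(/C=C/c3ccccc3)c12`, which differs from compound 3 in one place: 2-phenylethenyl in place of 2-methylphenyl on an aromatic carbon. In plain words, 2-phenylethenyl stands in place of 2-methylphenyl on an aromatic carbon. The carbon-only aromatic ring remains, and a double bond outside aromatic rings is added.

Among the compounds with values here, no measured compound carries this group, so the evidence is indirect. Within the data shown here, the only steps at this place are the two large ones into compound 3, and they show how far this assay can move when this group changes. Compound 4 resembles compound 3 in its aromatic ring, yet it also has a non-aromatic multiple bond, as compound 1 does at 20 nM. A value between these two is therefore expected, which means a sizeable move towards lower numbers, though smaller than the full gap. The expected step is a 33-fold lower number from compound 3 to compound 4 (1.52 log units; beyond the scatter). For compound 4 the estimated value is 2000 nM, with an expected range from 100 nM to 40000 nM.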

Compound 4, half-maximal inhibitory concentration: 1300 nM
The estimate for compound 4 lay 1.5-fold (0.19 log units) above the measured number; the measured number falls inside the stated range.
By their numbers in this assay, from the lowest: compounds 1 and 2 (each within the scatter of the next); then compound 4; then compound 3.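

Within the data shown here, compound 4 is the first compound here that keeps a carbon-only aromatic ring yet gives a number far from that of compound 3 in this assay, with a 51-fold lower number from compound 3 to compound 4 (1.71 log units; beyond the scatter). A ring of this kind at this position is therefore compatible with much stronger inhibition than compound 3 shows, at least when it is carried on 2-phenylethenyl rather than attached as 2-methylphenyl. The gain is only partial, however, since 2-phenylethenyl still trails both triple-bonded groups, with a 65-fold higher number from compound 2 to compound 4 (1.81 log units; beyond the scatter) and a 65-fold higher number from compound 1 to compound 4 (1.81 log units; beyond the scatter), and nothing measured here explains the size of these steps.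

From the compounds shown here alone, it remains open whether 2-phenylethynyl, which would join the aromatic ring to a triple bond, would match compound 1 and compound 2 or stay nearer compound 4, and the same holds for a saturated 2-phenylethyl group. The behaviour of a triple-bonded chain ending in an amine or a carboxylic acid is also unknown, as is that of a longer chain such as hept-1-yn-1-yl.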